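Swapping Chloro for Methoxy: Cytotoxicity at the Limit

The source may hold more compounds than are shown below. What is called first, only, known or untested is meant among the compounds shown, and "the series" means these compounds.

Three compounds share one core. Compound 1 `CCOc1ccc2nc(Cl)c(/C=C3\SC(=S)NC3=O)cc2c1` carries an ethoxy group on an aromatic carbon; in a toxicity assay on HeLa cells (Homo sapiens) for cytotoxicity, read by MTT assay, with a stated time of 48 h (a higher number here means a weaker inhibitor of growth, a lower number a stronger inhibitor of growth), compound 1 reaches only the limit > 100 ug/mL. Compound 2 `O=C1NC(=S)S/C1=C\c1cc2cc(Cl)ccc2nc1Cl` bears chloro at that place; in this assay compound 2 likewise stops at the limit > 100 ug/mL. Compound 3 `Cc1cccc2cc(/C=C3\SC(=S)NC3=O)c(Cl)nc12` is the third member; in this assay compound 3 also gives the limit > 100 ug/mL. The step that the two limits leave unreadable from compound 1 to compound 2 is therefore unreadable, since both of its ends sit at the limit of > 100 ug/mL in this assay, at which 3 of the 3 values shown sit. Compound 2 thus stands where every measured value stands: at a limit, with no number that would rank it against the other two.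

Compound 4 `COc1ccc2nc(Cl)c(/C=C3\SC(=S)NC3=O)cc2c1` differs from compound 2 by methoxy in place of chloro on an aromatic carbon. Among the compounds with values here, no measured step bears directly on this exchange; the only step available, a step that the two limits leave unreadable from compound 1 to compound 2, is itself unreadable. With all three known values resting at the limit of > 100 ug/mL in this assay, at which 3 of the 3 values shown sit, and the change touching only that one aromatic carbon, no shift beyond the scatter is expected in this assay. The step that the limit leaves unreadable from compound 2 to compound 4 is expected to be small. Compound 4 is therefore estimated at 150 ug/mL, within 70 ug/mL to 400 ug/mL, and most likely to be reported again as a limit rather than a number.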

Compound 4, concentration for 50% growth inhibition: > 100 ug/mL
Compound 4 was reported as a limit (the forecaster's own chance of this, stated with the estimate: 85%); the middle value does not contradict the limit.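

Compound 4 ends at a limit, so neither the step from compound 2 to compound 4 nor the step from compound 1 to compound 4 can be read, because all their ends sit at one limit: the limit of > 100 ug/mL in this assay, at which 4 of the 4 values shown sit.

The compounds shown leave open whether any change on the shared core shifts growth inhibition in this assay.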